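Pyridine in place of thiazole on a fused core

The source may report more compounds than this note shows. Statements on the series, on what has been measured and on what is new or still open speak of the compounds shown alone.

Compound 1: `c1cc(-c2nccs2)c2c(c1)C(c1ncc[nH]1)CC2`, > 10000 nM
Compound 2: `Cc1c(OCC2=NCCN2)ccc(Cl)c1NS(C)(=O)=O`, > 10000 nM

In a functional assay on CHO cells for agonist activity at Alpha-1B adrenergic receptor (Homo sapiens), read by FLIPR and calcium flux (a lower number here means that less compound is needed, a higher number that more compound is needed for the effect), compound 1 gives > 10000 nM, which is a limit of the assay and not a number. Compound 2 gives > 10000 nM in this assay, again only a limit. Both results sit at the limit of > 10000 nM in this assay, at which 2 of the 2 values shown sit, so compound 1 stands at the edge of what the assay can report. Compound 3 is `c1ccc(-c2cccc3c2CCC3c2ncc[nH]2)nc1`; it differs from compound 1 by pyridin-2-yl in place of 1,3-thiazol-2-yl on an aromatic carbon. Among the compounds with values here, no measured step covers such a change, so no direction can be drawn from the data. The expected step of a number no higher from compound 1 to compound 3 (the limit leaves the size open) is none beyond the scatter. Compound 3 is expected at 10000 nM, in a range from 3000 nM to 30000 nM.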

Compound 3, half-maximal effective concentration: > 10000 nM
Compound 3 ended at the assay's limit; the forecaster's own chance of this, stated with the estimate: 80%; the middle value lies on the limit itself.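

No step can be read between compound 1 and compound 3, since neither gives a number in this assay: the limit of > 10000 nM in this assay, at which 3 of the 3 values shown sit.

The compounds shown leave open whether pyridin-2-yl or 1,3-thiazol-2-yl on the shared core makes any difference to the amount of compound needed.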